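From nitro to tert-butyl on the aromatic ring

The source may hold more compounds than are shown below. What is called first, only, known or untested is meant among the compounds shown, and "the series" means these compounds.

Of the compounds shown here, two have been measured so far in a physicochemical assay for solubility, in phosphate buffer; a higher number here means a more soluble compound, a lower number a less soluble compound. Compound 1 (`Cc1cc(N[C@H](CCCCNCc2cccc(F)c2)C(=O)NO)cc(C)c1F`) gives > 5 ug/mL, which is a limit and not a number. Compound 2 (`Cc1cc(N[C@H](CCCCNCc2ccc([N+](=O)[O-])cc2)C(=O)NO)cc(C)c1F`) gives > 5 ug/mL, which is also a limit. Compound 2 therefore has no exact position in the series, and the overall picture is the limit of > 5 ug/mL in this assay, at which 2 of the 2 values shown sit.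

Compound 3 (`Cc1cc(N[C@H](CCCCNCc2ccc(C(C)(C)C)cc2)C(=O)NO)cc(C)c1F`) has tert-butyl in place of nitro on an aromatic carbon, para to a large group: tert-butyl in place of nitro on an aromatic carbon. Going by the values given here, the one measured step that bears on this change is a step that the two limits leave unreadable from compound 1 to compound 2. That step also exchanges the aromatic group, but it offers no size or direction to carry over, so no change beyond the scatter is expected in this assay. The expected step is a step that the limit leaves unreadable from compound 2 to compound 3. The estimate for compound 3 is 6 ug/mL, with an expected range from 2 ug/mL to 20 ug/mL. Another result reported only as a limit is quite possible.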

Compound 3, solubility: > 5 ug/mL
Compound 3: a limit, no number; the forecaster's own chance of this, stated with the estimate: 60%; the middle value does not contradict the limit.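

In this assay compound 3 gives > 5 ug/mL, which is a limit and not a number. The steps among compound 1, compound 2 and compound 3 therefore cannot be read, in size or in direction. Still open is whether 3-fluorophenyl, 4-nitrophenyl and 4-(tert-butyl)phenyl differ at all in this assay, as the series sits at one limit: the limit of > 5 ug/mL in this assay, at which 3 of the 3 values shown sit.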